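Oxazolidinone series: azetidinyl ketone replacing the hydroxy-isopropyl group

A few compounds are considered here, and "the series" means these few. Any claim that something is new, unique, unknown or untested is made for them only; others in the source may bear on it.

Measured compounds:
- compound 1, `CN1CCN(CCCC(=O)c2ccc(-c3ccc(N4C[C@H](Cn5ccnn5)OC4=O)cc3F)cn2)CC1`, 10500 nM in an assay for inhibition of Amine oxidase [flavin-containing] A (Homo sapiens); a lower number here means a stronger inhibitor, a higher number a weaker inhibitor
- compound 2, `CC(C)(O)c1ccc(-c2ccc(N3C[C@H](Cn4ccnn4)OC3=O)cc2F)cn1`, 6000 nM in this assay

Compound 2 holds the lowest of the two numbers in this assay, but its neighbour compound 1 sits within the scatter of it, so no order between them can be claimed. Within the data shown here, the one measured step, a 1.8-fold lower number from compound 1 to compound 2 (0.24 log units; within the scatter), is the only change on this aromatic carbon with a number attached.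

Compound 3, `O=C(c1ccc(-c2ccc(N3C[C@H](Cn4ccnn4)OC3=O)cc2F)cn1)C1CNC1`, not yet measured, carries the change ((azetidin-3-yl)carbonyl in place of 1-hydroxy-1-methylethyl on an aromatic carbon). The new group is a ketone of a small saturated ring with a basic nitrogen, so it resembles the ketone carried by compound 1 more than the tertiary alcohol of compound 2. Among the measured compounds shown here, the only step that bears on it is the one from compound 1 to compound 2, which lay within the scatter. The change is therefore expected to give no movement beyond the scatter, as a 1.3-fold higher number from compound 2 to compound 3 (0.12 log units; within the scatter). Compound 3 is expected to give about 8000 nM in this assay, between 3000 nM and 25000 nM.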

Compound 3, inhibition constant in the Amine oxidase [flavin-containing] A assay: 4500 nM
Compound 3: middle estimate off by 1.8-fold (0.25 log units), on the high side; low and high end bracket the measured number.
By their numbers in the Amine oxidase [flavin-containing] A assay, from the lowest: compounds 3, 2 and 1 (each within the scatter of the next, the first and the last beyond it).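

In the Amine oxidase [flavin-containing] A assay, compound 3 gives 4500 nM, and the (azetidin-3-yl)carbonyl group stands in for 1-hydroxy-1-methylethyl on this aromatic carbon without a step beyond the scatter (a 1.3-fold lower number from compound 2 to compound 3 (0.12 log units; within the scatter)). Among these compounds, in the Amine oxidase [flavin-containing] A assay, with the carbonyl kept, azetidin-3-yl in place of 3-(4-methylpiperazin-1-yl)propyl gives the first step that lies beyond the scatter, though a modest one (a 2.3-fold lower number from compound 1 to compound 3 (0.37 log units; beyond the scatter)). In a physicochemical assay for solubility, read by nephelometry (a lower number here means a less soluble compound, a higher number a more soluble compound), compound 2 gives 200000 nM and compound 3 gives 200000 nM, so the change from the tertiary alcohol to the ketone reads (no change at the digits printed from compound 2 to compound 3 (within the scatter)). No measured evidence accounts for either step in the inhibition data.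

The compounds shown do not separate the effect of the four-membered ring from that of shortening the chain on the carbonyl carbon. On these data alone, a methyl ketone or a piperidin-4-yl ketone at this position would test that, and how either would read remains open.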